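Amide variation on the shared core, cAMP efficacy

The source may hold more compounds than are shown below. What is called first, only, known or untested is meant among the compounds shown, and "the series" means these compounds.

Compound 1 `COc1cccc(-c2nc(SC)nc3sc(C(=O)N(C)C(C)(C)C)c(N)c23)c1` gives 47.8% in a functional assay on HEK293 cells for agonist activity at lutropin-choriogonadotropic hormone receptor (Homo sapiens), read by cAMP accumulation; on this read-out higher numbers stand for larger maximal responses and lower numbers for smaller maximal responses.
Compound 2 `COc1cccc(-c2nc(SC)nc3sc(C(=O)NN)c(N)c23)c1` gives 8.5%.
Compound 3 `COc1cccc(-c2nc(SC)nc3sc(C(=O)NCCO)c(N)c23)c1` gives 20.5%.

Compound 3 stands second highest of the three numbers. Its nearest neighbour is compound 2, with a number 12 percentage points higher from compound 2 to compound 3 (beyond the scatter); the furthest is compound 1, with a number 27.3 percentage points lower from compound 1 to compound 3 (beyond the scatter). Compound 4 `COc1cccc(-c2nc(SC)nc3sc(C(=O)NNC(C)(C)C)c(N)c23)c1` differs from compound 3 in one place: (tert-butyl)amino in place of 2-hydroxyethyl on an amide-type nitrogen.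

Going by the values given here, two measured steps bear on this. The step of a number 39.3 percentage points lower from compound 1 to compound 2 (beyond the scatter) was large; the step of a number 27.3 percentage points lower from compound 1 to compound 3 (beyond the scatter) was modest. Compound 4 therefore sits between compound 2, which bears an aminoamino group, and compound 1, which bears methyl(tert-butyl)amino on the carbonyl carbon. A modest rise in this assay is expected for compound 4, a number 9.5 percentage points higher from compound 3 to compound 4 (within the scatter). The estimate for compound 4 is 30%, with a range from 12% to 50%.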

Compound 4, largest response reached (reported as efficacy), in percent of the reference or control that the assay uses: 6%
For compound 4 the middle estimate is 24 percentage points above the measured one; measured number outside the range, below it.
By their numbers in this assay, from the lowest: compounds 4 and 2 (each within the scatter of the next); then compound 3; then compound 1.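

On the amide-type nitrogen, putting tert-butyl on the amine nitrogen gives no readable change in this assay (a number 2.5 percentage points lower from compound 2 to compound 4 (within the scatter)). Replacing 2-hydroxyethyl with (tert-butyl)amino gives a clear loss (a number 14.5 percentage points lower from compound 3 to compound 4 (beyond the scatter)). A tert-butyl group alone therefore does not carry the response of compound 1 over to compound 4 (a number 41.8 percentage points lower from compound 1 to compound 4 (beyond the scatter)). No measured evidence gives a cause for these steps.

Still open, as far as these compounds go, is whether a plain (tert-butyl)amino group on the carbonyl carbon, without the methyl of compound 1, keeps that response. A dimethylamino or piperidine amide would test how far the response depends on the tert-butyl group.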